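From 3,5-dichlorophenyl to 3-methoxyphenyl in compound 2

The source may hold more compounds than are shown below. What is called first, only, known or untested is meant among the compounds shown, and "the series" means these compounds.

In a functional assay on HL-60 cells (Homo sapiens) for inhibition, read by CCK-8 assay, with a stated time of 48 h (on this read-out lower numbers stand for stronger inhibition and higher numbers for weaker inhibition), compound 2 (`O=C(NCCNS(=O)(=O)c1ccc(-c2ccccc2Oc2ccc([N+](=O)[O-])c([N+](=O)[O-])c2)s1)Nc1cc(Cl)cc(Cl)c1`) gives 2300 nM and stands level with compound 1 (`O=C(NCCNS(=O)(=O)c1ccc(-c2ccccc2OCc2cccc(O)c2)s1)Nc1cc(Cl)cc(Cl)c1`) at 2800 nM on these numbers, the step being a 1.2-fold lower number from compound 1 to compound 2 (0.09 log units; within the scatter) here. Compound 3 (`O=C(NCCNS(=O)(=O)c1ccc(-c2ccccc2OCc2ccccc2)s1)Nc1cc(Cl)cc(Cl)c1`) gives 11700 nM as the highest number, with steps of (a 4.2-fold higher number from compound 1 to compound 3 (0.62 log units; beyond the scatter)) and (a 5.1-fold higher number from compound 2 to compound 3 (0.71 log units; beyond the scatter)) leading to it. Compound 4 (`COc1cccc(NC(=O)NCCNS(=O)(=O)c2ccc(-c3ccccc3Oc3ccc([N+](=O)[O-])c([N+](=O)[O-])c3)s2)c1`) carries the change 3-methoxyphenyl in place of 3,5-dichlorophenyl on an amide-type nitrogen at that place. Among the compounds with values here, no measured step touches this group, so the direction is uncertain and only the size of a 5.1-fold higher number from compound 2 to compound 3 (0.71 log units; beyond the scatter) offers a guide. For compound 4 a modest upward move is expected (a 2.4-fold higher number from compound 2 to compound 4 (0.38 log units; beyond the scatter)) in this assay on that basis. Compound 4 is estimated at 5500 nM (expected range 1800 nM to 16000 nM).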

Compound 4, half-maximal inhibitory concentration: 6700 nM
Compound 4: the middle estimate sits 1.2-fold (0.09 log units) below what was measured; the measured number falls inside the stated range.
By their numbers in this assay, from the lowest: compounds 2 and 1 (each within the scatter of the next); then compounds 4 and 3 (each within the scatter of the next).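

In this assay the group on the amide-type nitrogen proves able to move the number: 3-methoxyphenyl in place of 3,5-dichlorophenyl gives a 2.9-fold higher number from compound 2 to compound 4 (0.46 log units; beyond the scatter). Within the data shown here, compounds 1, 2 and 3 all carry 3,5-dichlorophenyl there, so this is the first reading of that place. Nothing available accounts for the step.

The compounds shown leave open whether the same change would give a step of like size in compound 1 or compound 3. They also leave open how a phenyl bearing an amine or a carboxylic acid would read at this place.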